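The source may report more compounds than this note shows. Statements on the series, on what has been measured and on what is new or still open speak of the compounds shown alone.

Measured in a functional assay on A549 cells (Homo sapiens) for inhibition, read by sulforhodamine B assay, with a stated time of 48 h; a lower number here means a stronger inhibitor of growth, a higher number a weaker inhibitor of growth:
- compound 1 `COc1ccc(/C=C/C(=O)C(=Cc2cccc(F)c2)C(=O)/C=C/c2ccc(OC)c(OC)c2)cc1OC`: 580 nM
- compound 2 `COc1ccc(/C=C/C(=O)C(=Cc2ccc(F)cc2)C(=O)/C=C/c2ccc(OC)c(OC)c2)cc1OC`: 550 nM
- compound 3 `COc1ccc(C=C(C(=O)/C=C/c2ccc(OC)c(OC)c2)C(=O)/C=C/c2ccc(OC)c(OC)c2)c(OC)c1`: 650 nM

Compound 3, at 650 nM, stands level with the other two within the scatter. Compound 4 `COc1ccc(/C=C/C(=O)C(=Cc2ccc(C)o2)C(=O)/C=C/c2ccc(OC)c(OC)c2)cc1OC` carries one change from it: 5-methylfuran-2-yl in place of 2,4-dimethoxyphenyl on a double-bonded chain carbon bound to a double-bonded chain carbon. The three measured steps all fall at this same place and are small: a 1.1-fold higher number from compound 1 to compound 3 (0.05 log units; within the scatter), a 1.2-fold higher number from compound 2 to compound 3 (0.07 log units; within the scatter) and a 1.1-fold lower number from compound 1 to compound 2 (0.02 log units; within the scatter). None of them involves a five-membered ring, so they bear on this change only indirectly. On that evidence, no shift beyond the scatter is expected in this assay. The expected size is a 1.3-fold lower number from compound 3 to compound 4 (0.10 log units; within the scatter). For compound 4 the estimated value is 520 nM, with an expected range of 220 nM to 1200 nM.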

Compound 4, concentration for 50% growth inhibition: 1310 nM
Beside the measured number, compound 4's estimate is 2.5-fold (0.40 log units) below it, and the stated range ends below it.
By their numbers in this assay, from the lowest: compounds 2, 1, 3 and 4 (each within the scatter of the next, the first and the last beyond it).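

In this assay, for the compounds shown here, the 5-methylfuran-2-yl group is the first at this place to separate from any other group beyond the scatter, though only modestly (a 2.4-fold higher number from compound 2 to compound 4 (0.38 log units; beyond the scatter); a 2.3-fold higher number from compound 1 to compound 4 (0.35 log units; beyond the scatter)). Against the 2,4-dimethoxyphenyl group, the same change stays within the scatter (a 2.0-fold higher number from compound 3 to compound 4 (0.30 log units; within the scatter)). Nothing available accounts for this result. The compounds shown leave open whether the methyl of the 5-methylfuran-2-yl group matters. They also leave open how a thiophen-2-yl group or a phenyl ring carrying an amine would read at this place.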